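The source may hold more compounds than are shown below. What is called first, only, known or untested is meant among the compounds shown, and "the series" means these compounds.

Measured so far:
- compound 1, `O=C(/C=C/c1coc2cc(O)ccc2c1=O)NCc1ccccc1` — in a functional assay on HeLa cells (Homo sapiens) for inhibition, read by MTT assay, with a stated time of 48 h (on this read-out higher numbers stand for weaker inhibition and lower numbers for stronger inhibition), compound 1 gives > 100000 nM, which is a limit of the assay, not a number
- compound 2, `COc1ccc2c(=O)c(/C=C/C(=O)NCc3ccccc3)coc2c1` — in this assay compound 2 gives 33400 nM

Compound 1 stands at the limit of > 100000 nM in this assay, at which 1 of the 2 values shown sits; only a limit is known for it, no number. Going by the values given here, compound 2 does give a number, and the step of an at least 2.9-fold lower number from compound 1 to compound 2 (0.47 log units; beyond the scatter) is the single measured step in the set.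

Compound 3, `O=C(/C=C/c1coc2cc(O)ccc2c1=O)Nc1ccccc1`, is not yet measured. It differs from compound 1 by phenyl in place of benzyl on an amide-type nitrogen. Among the compounds with values here, the one measured step, an at least 2.9-fold lower number from compound 1 to compound 2 (0.47 log units; beyond the scatter), concerns a methyl on a ring oxygen and leaves the amide nitrogen untouched, so it does not bear on the change from benzyl to phenyl. Within the data shown here, no measured step speaks to the group on the amide nitrogen. The expectation is therefore no step beyond the scatter, and compound 3 is expected to stay with compound 1 at the limit of > 100000 nM in this assay, at which 1 of the 2 values shown sits. For compound 3 the expected step is a step that the limit leaves unreadable from compound 1 to compound 3. For compound 3 the estimate is 150000 nM, with a range from 40000 nM to 500000 nM, most likely reported only as a limit.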

Compound 3, half-maximal inhibitory concentration: 9700 nM
Beside the measured number, compound 3's estimate is 15-fold (1.19 log units) above it; the measured number lies below the stated range.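

The amide nitrogen is a place where the series responds in this assay: with phenyl in place of benzyl, the result is an at least 10-fold lower number from compound 1 to compound 3 (1.01 log units; beyond the scatter). The earlier data showed a change only at the ring oxygen, through an at least 2.9-fold lower number from compound 1 to compound 2 (0.47 log units; beyond the scatter), so a second place in the shared core's substitution now moves the number, with the hydroxyl of compound 1 left as it was. The size of the new step is only a lower bound, since compound 1 has a limit of the assay and not a number: the limit of > 100000 nM in this assay, at which 1 of the 3 values shown sits.

Open, going by these compounds, is how the methyl on the ring oxygen and the phenyl on the amide nitrogen behave together in one compound, and whether the two changes would simply add up. Also open, on these data alone, is how far the response at the amide nitrogen extends: whether a longer chain such as phenylethyl in place of benzyl would continue the trend in the other direction, and how a carboxylic acid or an amine on the phenyl ring of compound 3 would read in this assay.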